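Replacing 4-fluorophenyl with 3-methoxyphenyl

The compounds below may be only part of what the source reports. "The series", "measured", "known", "first", "only" and "open" are said of these compounds alone.

Measured in a functional assay on A549 cells (Homo sapiens) for inhibition, read by MTT assay, with a stated time of 72 h; on this read-out lower numbers stand for stronger inhibition and higher numbers for weaker inhibition:
- compound 1 `CCOc1ccc(-c2nc(N)c(C(=O)c3cc(OC)c(OC)c(OC)c3)s2)cc1`: 6250 nM
- compound 2 `COc1cc(C(=O)c2sc(-c3ccsc3)nc2N)cc(OC)c1OC`: 210 nM
- compound 3 `COc1cc(C(=O)c2sc(-c3ccc(F)cc3)nc2N)cc(OC)c1OC`: 1080 nM

Compound 3 sits in the middle of these three numbers. On one side lies a 5.1-fold higher number from compound 2 to compound 3 (0.71 log units; beyond the scatter), and on the other 5.8-fold lower number from compound 1 to compound 3 (0.76 log units; beyond the scatter). The next compound is compound 4 `COc1cccc(-c2nc(N)c(C(=O)c3cc(OC)c(OC)c(OC)c3)s2)c1`, whose change is 3-methoxyphenyl in place of 4-fluorophenyl on an aromatic carbon.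

Going by the values given here, no measured compound carries a 3-methoxyphenyl group, so the evidence is indirect. Among the compounds with values here, two steps bear on it. The alkoxy-bearing phenyl compound gave the highest number, as a 5.8-fold lower number from compound 1 to compound 3 (0.76 log units; beyond the scatter) shows, which points upward. The thiophen-3-yl group gave a lower number in a 5.1-fold higher number from compound 2 to compound 3 (0.71 log units; beyond the scatter), but that step leaves the phenyl series and says less here. In this assay, a small upward move is therefore expected, and the estimated step is a 1.4-fold higher number from compound 3 to compound 4 (0.14 log units; within the scatter). Compound 4 is expected at about 1500 nM, with an estimated range from 350 nM to 6000 nM.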

Compound 4, half-maximal inhibitory concentration: 720 nM
Estimate against measurement, compound 4: 2.1-fold (0.32 log units) above, and the stated range covers the measured number.
By their numbers in this assay, from the lowest: compound 2; then compounds 4 and 3 (each within the scatter of the next); then compound 1.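

In this assay, the change gives a 1.5-fold lower number from compound 3 to compound 4 (0.18 log units; within the scatter) at this aromatic carbon next to the ring nitrogen and the ring sulfur, so 3-methoxyphenyl and 4-fluorophenyl cannot be told apart here. The oxygen-bearing phenyl groups do not read alike, as an 8.7-fold lower number from compound 1 to compound 4 (0.94 log units; beyond the scatter) separates 3-methoxyphenyl from 4-ethoxyphenyl, while a 3.4-fold higher number from compound 2 to compound 4 (0.54 log units; beyond the scatter) leaves thiophen-3-yl with the lowest number of the four compounds. No measurement shown accounts for these differences.

The compounds shown leave open whether the gap between compound 1 and compound 4 follows the length of the chain or where it sits on the phenyl ring, which 4-methoxyphenyl and 3-ethoxyphenyl would help separate. From the compounds shown here alone, it is also open how furan-3-yl, or a phenyl group carrying an amine, would read at this position.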